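Pentafluorophenylsulfonamides: swapping the para substituent on the anilide

A few compounds are considered here, and "the series" means these few. Any claim that something is new, unique, unknown or untested is made for them only; others in the source may bear on it.

Compound 2 `CN(C)c1ccc(NS(=O)(=O)c2c(F)c(F)c(F)c(F)c2F)cc1` carries a dimethylamino group on the anilide ring of the shared pentafluorophenylsulfonamide core. In a functional assay on OVCAR-8 cells (Homo sapiens) for inhibition (a lower number here means a stronger inhibitor of growth, a higher number a weaker inhibitor of growth), compound 2 gives 372 nM, which is the highest of the two numbers in hand; its nearest neighbour, compound 1 `O=S(=O)(Nc1ccc2[nH]ccc2c1)c1c(F)c(F)c(F)c(F)c1F`, gives 50 nM in this assay, a gap that lies beyond the usual scatter. The next analogue, compound 3 `COc1ccc(NS(=O)(=O)c2c(F)c(F)c(F)c(F)c2F)cc1`, differs from compound 2 in one place: methoxy in place of dimethylamino on an aromatic carbon. For the measured compounds named here, no measured pair isolates this particular exchange, so its effect cannot be read from the existing data. With compound 2 already standing at the weak end of this assay, the expected step from compound 2 to compound 3 is a 1.3-fold higher number from compound 2 to compound 3 (0.13 log units; within the scatter), small and not beyond the scatter. Compound 3 is therefore estimated to give 500 nM in this assay, with a range from 150 nM to 1700 nM.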

Compound 3, concentration for 50% growth inhibition: 50 nM
Compound 3: middle estimate off by 10-fold (1.00 log units), on the high side, and the stated range ends above it.
By their numbers in this assay, from the lowest: compounds 1 and 3 (each within the scatter of the next); then compound 2.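

In this assay, methoxy in place of dimethylamino on an aromatic carbon para to a large group gives a 7.4-fold lower number from compound 2 to compound 3 (0.87 log units; beyond the scatter). For the compounds shown here, this pair is the first to isolate a single exchange at this position, and it shows that growth inhibition responds to the group placed there by more than the scatter. The two groups have the same hydrogen-bond donor and acceptor counts and no net charge, so those counts do not separate them, and nothing in hand accounts for the step.

On these data alone, how an ethoxy group, a chlorine atom or a carboxylic acid at this position would compare with methoxy remains open. Also open, as far as these compounds go, is whether the step holds beyond this one pair of compounds.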